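Working notes: a second fluoro step on the ring

This account rests on a few compounds, and the source may have more. Where it says the series, first, only, none or still open, it means among the compounds named here.

Measured in an ADME assay on HT-29 cells (Homo sapiens) for inhibition, read by MTT assay, with a stated time of 72 h; a lower number here means a stronger inhibitor, a higher number a weaker inhibitor:

compound 1, `C=CC(=O)Nc1cccc(Nc2nc(N/N=C/c3ccccc3F)ncc2Cl)c1`, gives 3500 nM
compound 2, `C=CC(=O)Nc1cccc(Nc2nc(N/N=C/c3ccc(F)cc3F)ncc2Cl)c1`, gives 4760 nM
compound 3, `C/C(=N\Nc1ncc(Cl)c(Nc2cccc(NC(=O)/C=C/CN(C)C)c2)n1)c1ccc(F)cc1`, gives 10200 nM

Compound 1 and compound 2 differ by fluoro in place of hydrogen on an aromatic carbon, and the step is a 1.4-fold higher number from compound 1 to compound 2 (0.13 log units; within the scatter), so the two values cannot be ordered. Compound 3 carries a different core; the difference between the two cores is not broken down here. Its value stands above those of compound 1 and compound 2, in both cases beyond the scatter.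

Compound 4, `C/C(=N\Nc1ncc(Cl)c(Nc2cccc(NC(=O)/C=C/CN(C)C)c2)n1)c1ccc(F)cc1F`, is not yet measured. It differs from compound 3 by fluoro in place of hydrogen on an aromatic carbon. For the measured compounds named here, this is the same kind of change as the one from compound 1 to compound 2, but the place differs: in the earlier pair the entering fluoro sits meta to a fluoro group and para to a large group, whereas here it sits ortho to a large group and meta to a fluoro group. Going by the values given here, the expectation for compound 4 rests on the one measured instance, where the step was a 1.4-fold higher number from compound 1 to compound 2 (0.13 log units; within the scatter), and a step of similar size is expected here, a 1.3-fold higher number from compound 3 to compound 4 (0.11 log units; within the scatter). Compound 4 is therefore expected to give about 13000 nM in this assay , with a likely range from 6000 nM to 28000 nM.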

Compound 4, half-maximal inhibitory concentration: 3460 nM
Beside the measured number, compound 4's estimate is 3.8-fold (0.57 log units) above it, and the stated range ends above it.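

In this assay, there is a 2.9-fold lower number from compound 3 to compound 4 (0.47 log units; beyond the scatter), so on the core of compound 3 the change from 4-fluorophenyl to 2,4-difluorophenyl gives a stronger inhibitor. The result does not repeat the earlier step, and the two steps differ: the same change on two cores in this assay, a 1.4-fold higher number (0.13 log units; within the scatter) from compound 1 to compound 2 and a 2.9-fold lower number (0.47 log units; beyond the scatter) from compound 3 to compound 4, 4.0-fold (0.60 log units) apart, beyond the scatter of two such steps. This shows that the effect of this change did not carry over from one of these pairs to the other, but it does not show that the core alone sets the outcome, since the entering fluoro also sits in a different place in each pair, and one pair per core gives no rule for any further core.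

Open, going by these compounds, is how the 4-fluorophenyl to 2,4-difluorophenyl change itself behaves on the core of compound 1, a comparison that would separate the core from the place of the fluoro. Also open, on these data alone, is whether the lower number for compound 4 is particular to fluoro, or whether another group in the same place, such as methoxy or a nitrile, would give a similar step.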